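Cyano in place of difluoromethyl on compound 1

This account rests on a few compounds, and the source may have more. Where it says the series, first, only, none or still open, it means among the compounds named here.

In a functional assay on Ramos cells (Homo sapiens) for cytotoxicity, read by CCK-8 assay, with a stated time of 72 h (a higher number here means a weaker inhibitor, a lower number a stronger inhibitor), compound 1 (`Cn1cc(NC(=O)c2cnc3ccc(N[C@@H]4CCCNC4)nn23)c(C(F)F)n1`) gives 11400 nM and compound 2 (`Cn1cc(NC(=O)c2cnc3ccc(N[C@@H]4CCCCNC4)nn23)c(C(F)F)n1`) gives 7200 nM, so the two stand within the scatter of each other. Compound 3 (`Cn1cc(NC(=O)c2cnc3ccc(N[C@@H]4CCCNC4)nn23)c(C#N)n1`) keeps the rest of compound 1 and carries cyano in place of difluoromethyl on an aromatic carbon. Among the compounds with values here, the only measured step, a 1.6-fold lower number from compound 1 to compound 2 (0.20 log units; within the scatter), puts azepan-3-yl in place of piperidin-3-yl, elsewhere in the molecule, and stays within the scatter. It bears on the new change only loosely. Within the data shown here, no measured step touches this aromatic carbon, and the data give no direction for the change. No step beyond the scatter is therefore expected in this assay, though the uncertainty is wide. The estimated step is a 1.1-fold higher number from compound 1 to compound 3 (0.02 log units; within the scatter). For compound 3 the estimate is 12000 nM, with an expected range from 4000 nM to 35000 nM.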

Compound 3, half-maximal inhibitory concentration: 28800 nM
Compound 3: the middle estimate sits 2.4-fold (0.38 log units) below what was measured; the range from low to high includes it.
By their numbers in this assay, from the lowest: compounds 2 and 1 (each within the scatter of the next); then compound 3.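

In this assay, cyano in place of difluoromethyl on this aromatic carbon gives a 2.5-fold higher number from compound 1 to compound 3 (0.40 log units; beyond the scatter), the first step among these compounds to lie beyond the scatter, and it runs towards a weaker inhibitor. The number at this position therefore responds to the group it carries, whereas a 1.6-fold lower number from compound 1 to compound 2 (0.20 log units; within the scatter) at the azepan-3-yl change does not leave the scatter. The step is modest, and nothing measured here explains it.

Open, as far as these compounds go, is whether the step reflects the departure of difluoromethyl or the arrival of cyano, which a methyl, a trifluoromethyl or a carboxamide group on the same carbon could help to separate. Also open, from the compounds shown here alone, is whether cyano would give a step of similar size on compound 2, with its azepan-3-yl group.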